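The source may hold more compounds than are shown below. What is called first, only, known or untested is meant among the compounds shown, and "the series" means these compounds.

In a functional assay on H157 cells (Homo sapiens) for antiproliferative activity, read by trypan blue exclusion (a lower number here means a stronger inhibitor, a higher number a weaker inhibitor), this small series sits close to the ceiling of what can be measured. Compound 1 `COc1ccc(/C=C/S(=O)(=O)Cc2ccc(OC)cc2)cc1` gives only the limit of this assay, > 20000 nM, which is a limit and not a number. Compound 2 `COc1cc(OC)c(/C=C/S(=O)(=O)Cc2cc(OC)c(OC)c(OC)c2)c(OC)c1` likewise stops at the limit > 20000 nM. Among the compounds with values here, compound 3 `COc1cc(OC)c(/C=C/S(=O)(=O)Cc2ccc(C#N)cc2)c(OC)c1` is the one member with a measured number, 15000 nM, and so stands as the only value among the three. The other two rest where the assay stops (the limit of > 20000 nM in this assay, at which 2 of the 3 values shown sit). Compound 4 `COc1cc(OC)c(/C=C/S(=O)(=O)Cc2ccc(O)cc2)c(OC)c1` keeps the core of compound 3 and carries hydroxy in place of cyano on an aromatic carbon. Within the data shown here, no measured step covers this change, so the expected step from compound 3 to compound 4 in this assay a 1.9-fold lower number from compound 3 to compound 4 (0.27 log units; within the scatter) is set as a modest gain, with a real chance of none beyond the scatter. Compound 4 is estimated at 8000 nM, between 2000 nM and 20000 nM.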

Compound 4, half-maximal inhibitory concentration: 20000 nM
The estimate for compound 4 lay 2.5-fold (0.40 log units) below the measured number, and the stated range covers the measured number.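

In this assay, within the data shown here, hydroxy in place of cyano on this aromatic carbon, para to a large group, gives the only step that can be read here, a 1.3-fold higher number from compound 3 to compound 4 (0.12 log units; within the scatter), so the two groups cannot be told apart at this position. Neither group moves the compound clear of the top of the measurable range: the limit of > 20000 nM in this assay, at which 2 of the 4 values shown sit.

From the compounds shown here alone, whether an amine, a carboxylic acid or a longer chain at this position would give a number clearly apart from these remains open. So does whether any group here could bring the series well away from that limit.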